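This account rests on a few compounds, and the source may have more. Where it says the series, first, only, none or still open, it means among the compounds named here.

Measured compounds:
compound 1 `CNC(=O)c1cc(C(=O)NC2CC2)c(C)n(Cc2ccccc2)c1=O` gives 2.9
compound 2 `CNC(=O)c1cc(C(=O)NC2CC2)cn(Cc2ccc3nc[nH]c3c2)c1=O` gives 1.2
compound 3 `CNC(=O)c1cc(C(=O)NCCO)cn(Cc2ccccc2)c1=O` gives 1.9

In a physicochemical assay for lipophilicity, at pH 7.4 (a lower number here means a more polar compound, a higher number a more lipophilic compound), compound 2 stands lowest of the three numbers. Its nearest neighbour is compound 3, whose value in this assay lies higher by more than the scatter, and the furthest is compound 1, higher still and well beyond the scatter. Compound 4 `CNC(=O)c1cc(C(=O)NC2CC2)cn(Cc2cccc3occc23)c1=O` has not yet been measured in this assay. It differs from compound 2 in one place: 1-benzofuran-4-yl in place of 1H-benzimidazol-6-yl on a saturated chain carbon bound to an aromatic nitrogen. The benzimidazole that leaves carries a hydrogen-bond donor; the benzofuran that enters carries none, and it holds one oxygen where the leaving group holds two nitrogens.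

Within the data shown here, no measured pair in this set isolates this exchange, so the size of the step has to be judged from the spread between compound 2 and the benzyl-bearing compounds 1 and 3. On that basis the step from compound 2 to compound 4 in this assay is expected to be upward and clearly beyond the scatter, a number 1.80 log units higher from compound 2 to compound 4 (beyond the scatter). Compound 4 is expected to give about 3 in this assay, within a range from 2.5 to 3.5.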

Compound 4, distribution coefficient: 3.4
The estimate for compound 4 lay 0.40 log units below the measured number, and the stated range covers the measured number.
By their numbers in this assay, from the lowest: compound 2; then compound 3; then compound 1; then compound 4.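

In this assay, 1-benzofuran-4-yl in place of 1H-benzimidazol-6-yl on a saturated chain carbon bound to an aromatic nitrogen gives a number 2.20 log units higher from compound 2 to compound 4 (beyond the scatter), a large step and the first in this set that can be read at a single place. The exchange keeps the count of heavy atoms and of hydrogen-bond acceptors and loses the one hydrogen-bond donor, while everything else in compound 2 stays the same, so this one place alone can move the number this far. Nothing measured here accounts for the size of the step.

The compounds shown leave open where an indole, or a phenyl ring carrying an amine or a carboxylic acid, would stand at this place. They also leave open whether the same exchange gives a step of similar size with the other groups of compound 1 or compound 3 in the molecule.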